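Swapping a ring-bearing amide for a carbamate on the shared core

This account rests on a few compounds, and the source may have more. Where it says the series, first, only, none or still open, it means among the compounds named here.

Compound 1 `Cc1cc(C(=O)Nc2ccccn2)nn1Cc1cc(Cl)ccc1OCc1ccccc1`; in an assay on CHO-K1 cells for displacement of a labelled ligand from prostaglandin E2 receptor EP1 subtype (Homo sapiens) (on this read-out higher numbers stand for weaker inhibition and lower numbers for stronger inhibition), compound 1 gives 126 nM.
Compound 2 `Cc1cc(C(=O)NCc2ccccc2)nn1Cc1cc(Cl)ccc1OCc1ccccc1`; in this assay compound 2 gives 39.8 nM.
Compound 3 `Cc1cc(NC(=O)C2CCCO2)nn1Cc1cc(Cl)ccc1OCc1ccccc1`; in this assay compound 3 gives 39.8 nM.

Compound 3 stands level with compound 2 at the digits shown, and together they hold the lowest two numbers of the three; compound 1 is the furthest away, as the step of a 3.2-fold lower number from compound 1 to compound 3 (0.50 log units; beyond the scatter) shows. The move no change at the digits printed from compound 2 to compound 3 (within the scatter), which replaced the whole benzylcarbamoyl side group with a ((oxolan-2-yl)carbonyl)amino group, left the number unchanged.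

Compound 4 `Cc1cc(NC(=O)OCC(C)C)nn1Cc1cc(Cl)ccc1OCc1ccccc1` keeps everything of compound 3 except one spot: isobutoxy in place of oxolan-2-yl on a carbonyl carbon. Going by the values given here, no measured step alters this exact position. The steps of a 3.2-fold lower number from compound 1 to compound 2 (0.50 log units; beyond the scatter) and a 3.2-fold lower number from compound 1 to compound 3 (0.50 log units; beyond the scatter) were both modest, and the larger rearrangement in no change at the digits printed from compound 2 to compound 3 (within the scatter) made no difference at all, so changes around this side group have so far produced small or no effects. Compound 4 is therefore expected to show a step of about a 1.0-fold higher number from compound 3 to compound 4 (0.00 log units; within the scatter), nothing beyond the scatter. Compound 4 is estimated at 40 nM, within a range from 13 nM to 130 nM.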

Compound 4, half-maximal inhibitory concentration: 25.1 nM
Beside the measured number, compound 4's estimate is 1.6-fold (0.20 log units) above it, within the range that was stated.
By their numbers in this assay, from the lowest: compounds 4, 2 and 3 (each within the scatter of the next); then compound 1.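

Replacing the oxolan-2-yl ring with open-chain isobutoxy on the carbonyl carbon, with the same count of heavy atoms, shows that this position can lose its ring without a change beyond the scatter in this assay (a 1.6-fold lower number from compound 3 to compound 4 (0.20 log units; within the scatter)). The (isobutoxycarbonyl)amino group also matches the benzylcarbamoyl group within the scatter (a 1.6-fold lower number from compound 2 to compound 4 (0.20 log units; within the scatter)), so these two quite different side groups cannot be told apart on this read-out. Against the (pyridin-2-yl)carbamoyl group of compound 1, however, the difference is clear (a 5.0-fold lower number from compound 1 to compound 4 (0.70 log units; beyond the scatter)). No evidence is available that could explain these results.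

On these data alone, it remains open whether a longer chain in place of isobutoxy on the carbonyl carbon would keep the number level or move it beyond the scatter. The same question stands for an amine at this place.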